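Moving the ether oxygen along a side chain

The source may report more compounds than this note shows. Statements on the series, on what has been measured and on what is new or still open speak of the compounds shown alone.

Measured in a functional assay on MV4-11 cells (Homo sapiens) for antiproliferative activity, read by CellTiter-Glo, with a stated time of 72 h (on this read-out lower numbers stand for stronger inhibition of growth and higher numbers for weaker inhibition of growth), so far
Compound 1 `N[C@H]1CC[C@H](Nc2cc(-c3csc(NCC4CCOCC4)n3)c(Cl)cn2)CC1` gives 140 nM
Compound 2 `O=C(N[C@H]1CC[C@H](Nc2cc(-c3csc(NCC4CCOCC4)n3)c(Cl)cn2)CC1)C1CC1` gives > 10000 nM (a limit)
Compound 3 `COCCCN[C@H]1CC[C@H](Nc2cc(-c3csc(NCC4CCOCC4)n3)c(Cl)cn2)CC1` gives 1090 nM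

The value of compound 2 is a limit of the assay. Compound 3 holds the higher of the two true numbers, with a 7.8-fold higher number from compound 1 to compound 3 (0.89 log units; beyond the scatter) as its gap.

Compound 4 `CCOCCN[C@H]1CC[C@H](Nc2cc(-c3csc(NCC4CCOCC4)n3)c(Cl)cn2)CC1` has not yet been measured. The change is ethoxy in place of methoxymethyl on a saturated chain carbon, two bonds along the chain from an amine nitrogen and so 3-methoxypropyl becomes 2-ethoxyethyl with the same atoms joined differently.

The measured steps all alter the group on that nitrogen. The large one is an at least 71-fold higher number from compound 1 to compound 2 (1.85 log units; beyond the scatter) and the modest one is a 7.8-fold higher number from compound 1 to compound 3 (0.89 log units; beyond the scatter) while an at least 9.1-fold lower number from compound 2 to compound 3 (0.96 log units; beyond the scatter) is at least modest. None of them rearranges a chain, so the nearest guide is compound 3 at 1090 nM in this assay and no step beyond the scatter is expected.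

The estimated step is a 1.1-fold lower number from compound 3 to compound 4 (0.04 log units; within the scatter) in size. Compound 4 is expected at 1000 nM with an estimated range from 450 nM to 2500 nM in this read-out.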

Compound 4, concentration for 50% growth inhibition: 497 nM
Beside the measured number, compound 4's estimate is 2.0-fold (0.30 log units) above it; measured number inside the range.
By their numbers in this assay, from the lowest: compound 1; then compound 4; then compound 3. At a limit, above all of these: compound 2.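

In this assay, the side chain on the amine nitrogen responds to the place of its ether oxygen alone, with the atoms unchanged: 3-methoxypropyl to 2-ethoxyethyl gives a 2.2-fold lower number from compound 3 to compound 4 (0.34 log units; beyond the scatter), yet the free amine is not matched, with a 3.6-fold higher number from compound 1 to compound 4 (0.55 log units; beyond the scatter). The alkylated amine also stays far ahead of the cyclopropylcarbonyl amide, with an at least 20-fold lower number from compound 2 to compound 4 (1.30 log units; beyond the scatter). That step rests on a limit of the assay for compound 2: the limit of > 10000 nM in this assay, at which 1 of the 4 values shown sits.

The compounds shown hold only this one pair of chains with the same atoms, so they do not separate the place of the oxygen from the ethyl end it now carries. Going by these compounds, how a 2-methoxyethyl chain, a longer 2-propoxyethyl chain or a chain ending in a hydroxyl group would compare stays open.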